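Weak Cytotoxicity in a Benzenesulfonamide Series: Forecasting Compound 3

A few compounds are considered here, and "the series" means these few. Any claim that something is new, unique, unknown or untested is made for them only; others in the source may bear on it.

Measured compounds:
compound 1, `NS(=O)(=O)c1cc(-c2nnc(Cn3cc(-c4ccccc4)nn3)o2)c(Cl)cc1SCc1ccccc1`: 75000 nM
compound 2, `COc1ccc(-c2cn(Cc3nnc(-c4cc(S(N)(=O)=O)c(SCc5ccccc5)cc4Cl)o3)nn2)cc1`: 190000 nM

In a functional assay on HCT-116 cells (Homo sapiens) for cytotoxicity, read by MTT assay, with a stated time of 72 h (on this read-out higher numbers stand for weaker inhibition and lower numbers for stronger inhibition), compound 1 gives 75000 nM, the lowest of the two numbers. Compound 2 gives 190000 nM. Among the measured compounds shown here, the one measured step, a 2.5-fold higher number from compound 1 to compound 2 (0.40 log units; beyond the scatter), follows a methoxy in place of hydrogen on an aromatic carbon.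

Compound 3, `NS(=O)(=O)c1cc(-c2nnc(/C=C/c3ccc(Br)cc3)o2)c(Cl)cc1SCc1ccccc1`, differs from compound 1 by 2-(4-bromophenyl)ethenyl in place of (4-phenyl-1H-1,2,3-triazol-1-yl)methyl on an aromatic carbon. For the measured compounds named here, no measured step touches this kind of change, so there is nothing to point in either direction. Compound 3 is therefore expected to stay close to compound 1, with the expected step of a 1.2-fold lower number from compound 1 to compound 3 (0.06 log units; within the scatter) lying within the scatter. Compound 3 is estimated at 65000 nM, between 15000 nM and 280000 nM.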

Compound 3, half-maximal inhibitory concentration: 15000 nM
Compound 3: middle estimate off by 4.3-fold (0.64 log units), on the high side; the measured number falls inside the stated range.
By their numbers in this assay, from the lowest: compound 3; then compound 1; then compound 2.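

In this assay, the group on the aromatic carbon next to the ring nitrogen and the ring oxygen can shift the number, which the earlier methoxy step did not test: replacing (4-phenyl-1H-1,2,3-triazol-1-yl)methyl with 2-(4-bromophenyl)ethenyl gives a 5.0-fold lower number from compound 1 to compound 3 (0.70 log units; beyond the scatter) and thus moves it beyond the scatter. The change swaps the whole group at once, so the step belongs to the exchange as a whole. No available evidence bears on this step.

From the compounds shown here alone, whether the bromine, the double bond or the loss of the triazole carries the step remains open. An amine or a carboxylic acid in place of the bromine also remains untested in the compounds shown.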